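A few compounds are considered here, and "the series" means these few. Any claim that something is new, unique, unknown or untested is made for them only; others in the source may bear on it.

Measured compounds in an assay on HeLa cells for inhibition of Indoleamine 2,3-dioxygenase 1 (Homo sapiens), read by spectrophotometry, with a stated time of 24 h; a lower number here means that less compound is needed, a higher number that more compound is needed for the effect:
Compound 1, `CS(=O)(=O)NNc1nonc1/C(=N/O)Nc1ccc(F)c(Br)c1`: compound 1 reaches only the limit of this assay, > 800 nM.
Compound 2, `NS(=O)(=O)CCNc1nonc1/C(=N/O)Nc1ccc(F)c(Br)c1`: compound 2 gives 11 nM.
Compound 3, `O=S(=O)(CCNc1nonc1/C(=N/O)Nc1ccc(F)c(Br)c1)NCC1CC1`: compound 3 gives 268 nM.

Among the two numbers actually recorded in this assay, compound 3 stands at the higher one; its nearest neighbour is compound 2, and the step of a 24-fold higher number from compound 2 to compound 3 (1.39 log units; beyond the scatter) separates them. Compound 1 contributes no number, only a limit, (the limit of > 800 nM in this assay, at which 1 of the 3 values shown sits).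

Compound 4, `NNS(=O)(=O)CCNc1nonc1/C(=N/O)Nc1ccc(F)c(Br)c1`, differs from compound 3 in one place: amino in place of cyclopropylmethyl on a sulfonamide nitrogen. The step that bears most directly on this change is a 24-fold higher number from compound 2 to compound 3 (1.39 log units; beyond the scatter), where placing cyclopropylmethyl on the sulfonamide nitrogen of compound 2 raised the number by a large margin. Compound 4 undoes that and puts a small amino group in its place, so the sulfonamide end of compound 4 resembles compound 2 far more than compound 3. The other step, an at least 72-fold lower number from compound 1 to compound 2 (1.86 log units; beyond the scatter), concerns a different position and starts from a limit, so it informs the expectation only loosely.

Compound 4 is therefore expected to give about 25 nM in this assay, with a likely range from 8 nM to 90 nM. This corresponds to an expected step of an 11-fold lower number from compound 3 to compound 4 (1.03 log units; beyond the scatter).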

Compound 4, half-maximal effective concentration: > 800 nM
Compound 4: no number, only a limit (the forecaster's own chance of this, stated with the estimate: 5%); middle value at least 32-fold (1.50 log units) from the limit.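

In this assay, the sulfonamide nitrogen had so far shown a single change away from hydrogen, a 24-fold higher number from compound 2 to compound 3 (1.39 log units; beyond the scatter), which left open whether a group with fewer heavy atoms than cyclopropylmethyl would stay closer to compound 2. Amino, with its one nitrogen, does not: the result is an at least 72-fold higher number from compound 2 to compound 4 (1.86 log units; beyond the scatter), and also an at least 2.9-fold higher number from compound 3 to compound 4 (0.47 log units; beyond the scatter), so on this nitrogen the group with one heavy atom lies further from hydrogen than cyclopropylmethyl with four heavy atoms, and the number does not follow the count of heavy atoms across these three compounds. Compound 4 gives only a limit and not a number: the limit of > 800 nM in this assay, at which 2 of the 4 values shown sit.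

As far as these compounds go, how far compound 4 lies past that limit remains open, and the step from compound 1, which is also a limit, cannot be read. The compounds shown also leave open whether a methyl group or a hydroxyl on the sulfonamide nitrogen would fall nearer to compound 2 or nearer to compound 4.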